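An Alkyne in Place of the Hydroxybutyl Chain

This account rests on a few compounds, and the source may have more. Where it says the series, first, only, none or still open, it means among the compounds named here.

Of the compounds shown here, three built on one shared core have been measured in an assay on HEK293 cells for agonist activity at Toll-like receptor 8 (Homo sapiens), read by spectrophotometry; on this read-out lower numbers stand for an effect already at smaller amounts and higher numbers for an effect only at larger amounts of compound. Compound 1 `CCCCNc1nc(N)nc(C)c1CCCCO` gives 1310 nM, the highest of the three numbers. Compound 2 `CCCCNc1nc(N)nc(C)c1CCc1ccccc1` gives 1190 nM, and compound 3 `CCCCNc1nc(N)nc(C)c1CCCc1ccccc1` gives 749 nM. The step of a 1.1-fold lower number from compound 1 to compound 2 (0.04 log units; within the scatter) and the step of a 1.7-fold lower number from compound 1 to compound 3 (0.24 log units; within the scatter) both remain within the scatter, as does a 1.6-fold lower number from compound 2 to compound 3 (0.20 log units; within the scatter), so the three numbers cannot be told apart.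

Compound 4 `CCCC#Cc1c(C)nc(N)nc1NCCCC` has not yet been measured. Its difference from compound 1 is pent-1-yn-1-yl in place of 4-hydroxybutyl on an aromatic carbon. Both measured steps from compound 1 bear on this change: each of them, a 1.1-fold lower number from compound 1 to compound 2 (0.04 log units; within the scatter) and a 1.7-fold lower number from compound 1 to compound 3 (0.24 log units; within the scatter), also takes the hydroxyl group away and stays within the scatter. Within the data shown here, the change to compound 4 removes the hydroxyl group as well, but brings in a chain carrying a triple bond rather than a ring, for which no measured step exists. On this basis the expected step of a 1.3-fold lower number from compound 1 to compound 4 (0.12 log units; within the scatter) is small, at most a slightly lower number and nothing beyond the scatter. Compound 4 is therefore estimated to give about 1000 nM in this assay, within a range from 400 nM to 2500 nM.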

Compound 4, half-maximal effective concentration: 5000 nM
Estimate against measurement, compound 4: 5.0-fold (0.70 log units) below, and the stated range ends below it.
By their numbers in this assay, from the lowest: compounds 3, 2 and 1 (each within the scatter of the next); then compound 4.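

At the aromatic carbon ortho to the butylamino group and ortho to the methyl group, pent-1-yn-1-yl in place of 4-hydroxybutyl gives a 3.8-fold higher number from compound 1 to compound 4 (0.58 log units; beyond the scatter) in this assay, the first step from compound 1 that lies beyond the scatter, although both chains have 5 heavy atoms and neither has a ring. Compound 2 and compound 3 also lack the hydroxyl group, yet their steps from compound 1 stay within the scatter, so among these compounds losing the hydroxyl group does not by itself go with a higher number; compound 4 is the one with a triple bond outside the aromatic ring, and it alone stands apart. Nothing measured here accounts for this shift.

The compounds shown leave open whether the triple bond or something else about the straight unbranched chain goes with the higher number, and a saturated pentyl chain on the same carbon would test this directly. A 5-hydroxypent-1-yn-1-yl group there would show whether a hydroxyl group at the end of the alkyne chain brings the number back toward that of compound 1.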